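A few compounds are considered here, and "the series" means these few. Any claim that something is new, unique, unknown or untested is made for them only; others in the source may bear on it.

Working notes on the triazole series

Compound 1 `CN(Cc1cn(CC(O)COC(=O)c2ccccc2)nn1)CC1CCCCC1` gives 6% in an assay on nucleic acid for inhibition of Nucleic Acid, read by fluorescence, tested at 100 uM; on this read-out higher numbers stand for more inhibition at the one concentration tested (going by the name of the read-out) and lower numbers for less inhibition. Compound 2 `CCCCC(O)Cn1cc(CN(C)CC2CCCCC2)nn1` gives 47% in this assay. The difference between the two is propyl in place of benzoyloxy on a saturated chain carbon, two bonds along the chain from an oxygen on a saturated carbon, and the step it makes is a number 41 percentage points higher from compound 1 to compound 2 (beyond the scatter). Compound 3 `CCCCN(CCCC)Cc1cn(CC(O)COC(=O)c2ccccc2)nn1` gives 12% in this assay. It differs from compound 1 in its core by dibutylamino in place of (cyclohexylmethyl)(methyl)amino on a saturated chain carbon bound to an aromatic carbon, and this step is a number 6 percentage points higher from compound 1 to compound 3 (within the scatter), so the two values of compound 1 and compound 3 are not separated here.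

Compound 4 `CCCCC(O)Cn1cc(CN(CCCC)CCCC)nn1` has not yet been measured in this assay. It differs from compound 3 by propyl in place of benzoyloxy on a saturated chain carbon, two bonds along the chain from an oxygen on a saturated carbon, which is the same change seen from compound 1 to compound 2; among the four compounds this change occurs twice, once measured and once not. The place of the change is described in the same words for both pairs.

For compound 4 a step of a number 38 percentage points higher from compound 3 to compound 4 (beyond the scatter) is expected in this assay, resting on the earlier step of a number 41 percentage points higher from compound 1 to compound 2 (beyond the scatter) made on the other core. The estimate for compound 4 in this assay is 50%, expected to fall between 28% and 72%.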

Compound 4, a percentage reported as inhibition, at one concentration (the size of the read-out at that concentration, not a potency): 18%
For compound 4 the middle estimate is 32 percentage points above the measured one; the whole stated range lies above it.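

On the core of compound 3, the change from benzoyloxy to propyl gives a number 6 percentage points higher from compound 3 to compound 4 (within the scatter), so the two compounds are not separated in this assay. The step therefore does not carry over at the same size from the core of compound 1 to the core of compound 3: the same change on two cores in this assay, a number 41 percentage points higher (beyond the scatter) from compound 1 to compound 2 and a number 6 percentage points higher (within the scatter) from compound 3 to compound 4, 35 percentage points apart, beyond the scatter of two such steps

This shows that the result of the change in this series depends on the core that carries it, but it does not show what produces the gap, and one pair on each core gives no rule for predicting the step on a further core. The compounds shown leave open whether the large step is confined to the (cyclohexylmethyl)(methyl)amino group or would also appear with another amine, such as dipropylamino. They also leave open how a longer chain, such as hexyl, in place of propyl would read on either core.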